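Shortening the Amine Chain on a Second Core

The compounds below may be only part of what the source reports. "The series", "measured", "known", "first", "only" and "open" are said of these compounds alone.

Four compounds share much of their structure, and the question is how a cell-toxicity read-out responds when the chain on the amine is shortened. Compound 1 `CCCCCNc1nc(SC)nc(CCO)c1Br` is the reference; in an ADME assay on Vero cells (Chlorocebus sabaeus) for cytotoxicity, with a stated time of 48 h (on this read-out higher numbers stand for lower toxicity in this test and lower numbers for higher toxicity in this test), compound 1 gives 93300 nM. Compound 2 `C#CCNc1nc(SC)nc(CCO)c1Br` differs from it by ethynyl in place of butyl on a saturated chain carbon bound to a nitrogen on an aromatic ring, and in this assay compound 2 gives 827000 nM, so the change made an 8.9-fold higher number from compound 1 to compound 2 (0.95 log units; beyond the scatter).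

Compound 3 `CCCCCNc1cc(CCO)nc(SC)n1` sits on a second core. The difference between the two cores is hydrogen in place of bromo on an aromatic carbon, and that change gave a 2.6-fold higher number from compound 1 to compound 3 (0.42 log units; beyond the scatter). In this assay compound 3 gives 245000 nM, a number that stands below that of compound 2.

Compound 4 `C#CCNc1cc(CCO)nc(SC)n1` has not been measured. It differs from compound 3 by ethynyl in place of butyl on a saturated chain carbon bound to a nitrogen on an aromatic ring, the same change, at the same place, that carried compound 1 to compound 2. Going by the values given here, there is only this one earlier example of the change, and it was seen on the other core, so its size on the new core cannot be taken as fixed. Still, the direction is the natural starting point. Because the same change made an 8.9-fold higher number from compound 1 to compound 2 (0.95 log units; beyond the scatter), compound 4 is expected to show a step of about a 5.3-fold higher number from compound 3 to compound 4 (0.72 log units; beyond the scatter) in this assay. Compound 4 is therefore estimated at roughly 1300000 nM, with a plausible range from 500000 nM to 3000000 nM.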

Compound 4, half-maximal cytotoxic concentration: 1120000 nM
For compound 4 the middle estimate is 1.2-fold (0.06 log units) above the measured one; low and high end bracket the measured number.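

Carried to the second core, the change from pentyl to propargyl again gave a higher number in this assay, and the step on this core, a 4.6-fold higher number from compound 3 to compound 4 (0.66 log units; beyond the scatter), does not differ from the earlier one: the same change on two cores in this assay, an 8.9-fold higher number (0.95 log units; beyond the scatter) from compound 1 to compound 2 and a 4.6-fold higher number (0.66 log units; beyond the scatter) from compound 3 to compound 4, 1.9-fold (0.29 log units) apart, within the scatter of two such steps. The other change, hydrogen in place of bromo, can be read on the propargyl compounds as well, where it gives a 1.4-fold higher number from compound 2 to compound 4 (0.13 log units; within the scatter), and this step likewise does not differ from its counterpart on the pentyl compounds: the same change on two cores in this assay, a 2.6-fold higher number (0.42 log units; beyond the scatter) from compound 1 to compound 3 and a 1.4-fold higher number (0.13 log units; within the scatter) from compound 2 to compound 4, 1.9-fold (0.29 log units) apart, within the scatter of two such steps. Together these two comparisons show that, across this small square of four compounds, each change behaved much the same whichever the other group was, but they rest on one pair of cores and one read-out, so they do not show that the same would hold on any further core, nor why the number moves.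

The step from pentyl to propargyl alters chain length and adds a triple bond at once, so the compounds shown leave open which of the two goes with the higher number, a question that a plain propyl chain on the amine could help to separate. From the compounds shown here alone, it also remains open how other groups in place of bromo, such as chloro, would fit this picture.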